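The compounds below may be only part of what the source reports. "The series", "measured", "known", "first", "only" and "open" are said of these compounds alone.

Working notes on the series. For the measured compounds named here, the three measured members share one core and differ at the acyl end or in ring methylation. Compound 1 `Cc1c(OCCCCOc2ccc(C(=O)O)cc2)ccc(C(=O)CC(C)C)c1O` gives 51.9% in an assay on HEK293 cells for positive allosteric modulation of metabotropic glutamate receptor 3 (Rattus norvegicus), read by thallium flux, with a stated time of 2.5 min; on this read-out higher numbers stand for larger maximal responses and lower numbers for smaller maximal responses. Compound 2 `CCCC(=O)c1ccc(OCCCCOc2ccc(C(=O)O)cc2C)c(C)c1O` gives 40.5% in this assay. Compound 3 `Cc1c(OCCCCOc2ccc(C(=O)O)cc2)ccc(C(=O)CC2CCCC2)c1O` gives 26.7% in this assay, the lowest of the three numbers; the gap to compound 2 and the larger gap to compound 1 are both beyond the scatter. Going by the values given here, the only single-site step so far is a number 25.2 percentage points lower from compound 1 to compound 3 (beyond the scatter).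

Compound 4 `COC(=O)c1ccc(OCCCCOc2ccc(C(=O)CC3CCCC3)c(O)c2C)cc1` is the next member, not yet measured. It differs from compound 3 by methyl in place of hydrogen on an oxygen next to a carbonyl group, so the carboxy becomes methoxycarbonyl at the far end of the chain. Among the compounds with values here, no measured step touches this end of the molecule: the one known step concerns the acyl side and says nothing about the acid. Within the data shown here, with no comparable step available, the expectation for compound 4 in this assay is a change of a number 1.3 percentage points higher from compound 3 to compound 4 (within the scatter), within the scatter. Compound 4 is therefore estimated at 28%, with a range from 10% to 50%.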

Compound 4, largest response reached (reported as percent of maximum), in percent of the reference or control that the assay uses: 22%
The estimate for compound 4 lay 6 percentage points above the measured number; the measured number falls inside the stated range.
By their numbers in this assay, from the lowest: compounds 4 and 3 (each within the scatter of the next); then compound 2; then compound 1.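

Methyl in place of hydrogen on an oxygen next to a carbonyl group, which turns the carboxy into methoxycarbonyl, gives a number 4.7 percentage points lower from compound 3 to compound 4 (within the scatter) in this assay and is the first reading at this end of the molecule. With the cyclopentyl acyl side held constant, a free carboxy is therefore not required for a response of this size, and this assay does not separate carboxy from methoxycarbonyl in this pair. Nothing at hand explains the outcome.

On these data alone, this reading rests on one pair, so whether methoxycarbonyl behaves the same way alongside the isopropyl acyl side of compound 1 remains open. Also open, as far as these compounds go, is how a primary amide or a tetrazole at the far end, or a longer linking chain, would compare with the carboxy.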